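The source may report more compounds than this note shows. Statements on the series, on what has been measured and on what is new or still open speak of the compounds shown alone.

Working notes on the series, read in a functional assay on HepG2 cells (Homo sapiens) for cytotoxicity, read by MTT assay, with a stated time of 24 h; on this read-out higher numbers stand for weaker inhibition and lower numbers for stronger inhibition. Compound 1 (`O=C1/C(=C/c2cccnc2)CNC/C1=C\c1ccccc1F`) gives 21000 nM, compound 2 (`O=C1/C(=C/c2ccncc2)CNC/C1=C\c1ccccc1F`) gives 8200 nM, and compound 3 (`O=C1/C(=C/c2ccncc2)CN(S(=O)(=O)c2ccccc2)C/C1=C\c1ccccc1F`) gives 5800 nM. Compound 2 thus lies within the scatter of compound 3 and clearly under compound 1.

The next compound is compound 4 (`O=C1/C(=C/c2ccncc2)CNC/C1=C\c1ccccc1C(F)(F)F`), with the change trifluoromethyl in place of fluoro on an aromatic carbon, ortho to a large group. Within the data shown here, no measured compound tests a change at this carbon, so the two measured steps serve only as a guide to size. The pyridin-4-yl for pyridin-3-yl exchange gives the modest 2.6-fold lower number from compound 1 to compound 2 (0.41 log units; beyond the scatter), and phenylsulfonyl in place of hydrogen on an amine nitrogen in a ring gives a 1.4-fold lower number from compound 2 to compound 3 (0.15 log units; within the scatter), which stays within the scatter. As far as these compounds go, on that basis no step beyond the scatter is expected in this assay, and the direction remains open, with only a slight lean to a lower number. The expected step is a 1.3-fold lower number from compound 2 to compound 4 (0.10 log units; within the scatter). For compound 4 the estimate is 6500 nM, with an expected range from 2500 nM to 17000 nM.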

Compound 4, half-maximal inhibitory concentration: 6130 nM
The estimate for compound 4 lay 1.1-fold (0.03 log units) above the measured number; measured number inside the range.
By their numbers in this assay, from the lowest: compounds 3, 4 and 2 (each within the scatter of the next); then compound 1.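

In this assay, among these compounds, the change of trifluoromethyl in place of fluoro on an aromatic carbon, ortho to a large group, gives a 1.3-fold lower number from compound 2 to compound 4 (0.13 log units; within the scatter) and is the first reading at this carbon of the series. Going from one heavy atom to four at this place does not carry the number beyond the scatter, so in this read-out the place accepts the larger group with no clear gain or loss. The step is also of the same small order as the one at the ring nitrogen, a 1.4-fold lower number from compound 2 to compound 3 (0.15 log units; within the scatter), although it lies at a different place in the molecule.

As far as these compounds go, whether an amine, a methoxy group or a carboxylic acid on this aromatic carbon would give a step beyond the scatter stays open. From the compounds shown here alone, it is equally open whether trifluoromethyl in place of fluoro reads the same on compound 1 or on compound 3, and no measured property bears on why this step is small.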